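Swapping methoxy for chloro in compound 3

This account rests on a few compounds, and the source may have more. Where it says the series, first, only, none or still open, it means among the compounds named here.

- compound 1 `CN1CCN(c2ccc(S(=O)(=O)Oc3cccc(Cl)c3)cc2)C1=O` gives 2200 nM 
- compound 2 `CCCN1CCN(c2ccc(S(=O)(=O)Oc3cccc(OC)c3)cc2)C1=O` gives 6300 nM 

Both numbers come from a functional assay on MCF7 cells (Homo sapiens) for antiproliferative activity, read by sulforhodamine B assay, with a stated time of 48 h; on this read-out higher numbers stand for weaker inhibition and lower numbers for stronger inhibition. Compound 2 has the higher of the two numbers, so it is the weaker inhibitor of this pair, and its gap to compound 1 lies beyond the usual scatter. These two compounds differ in more than one place, so their gap cannot be tied to any single change.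

Compound 3 `CCCN1CCN(c2ccc(S(=O)(=O)Oc3cccc(Cl)c3)cc2)C1=O` differs from compound 2 in one place, with chloro in place of methoxy on an aromatic carbon. Within the data shown here, no measured pair shows this change directly. Among the measured compounds shown here, the only guide is compound 1, which also carries chloro and gives 2200 nM with a different chain. A moderate step of a 2.5-fold lower number from compound 2 to compound 3 (0.40 log units; beyond the scatter) toward stronger inhibition is therefore expected. Compound 3 is estimated at 2500 nM within an expected range from 900 nM to 6500 nM.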

Compound 3, half-maximal inhibitory concentration: 380 nM
Beside the measured number, compound 3's estimate is 6.6-fold (0.82 log units) above it, outside the stated range (below it).
By their numbers in this assay, from the lowest: compound 3; then compound 1; then compound 2.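

In this assay, chloro in place of methoxy on this aromatic carbon can now be read on its own: it gives a 17-fold lower number from compound 2 to compound 3 (1.22 log units; beyond the scatter) and counts as a large step, so this one position strongly shapes the number. The chain matters too, since ethyl in place of hydrogen on the saturated chain carbon gives a 5.8-fold lower number from compound 1 to compound 3 (0.76 log units; beyond the scatter) as a modest step, an effect that the first pair could not separate from the change on the ring. No measurement shown here explains why either change moves the number.

As far as these compounds go, whether bromo, fluoro, trifluoromethyl or an amine at this position would match chloro remains open. So does whether a longer chain, such as butyl, would extend the gain seen with compound 3.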